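The compounds below may be only part of what the source reports. "The series", "measured", "known", "first", "only" and "open" are said of these compounds alone.

Compound 1 `CNC(=O)c1cc(Oc2ccc(NC(=O)c3cc4cccnc4n(-c4ccccc4F)c3=O)cc2)ccn1` serves as the starting point; in a functional assay on NCI-H460 cells (Homo sapiens) for antiproliferative activity, read by MTT assay, with a stated time of 72 h (a lower number here means a stronger inhibitor, a higher number a weaker inhibitor), compound 1 gives 590 nM. Compound 2 `CNC(=O)c1cc(Oc2ccc(NC(=O)c3cc4cccnc4n(-c4ccc(F)cc4)c3=O)cc2)ccn1` differs by 4-fluorophenyl in place of 2-fluorophenyl on an aromatic nitrogen, and in this assay compound 2 gives 210 nM, a step of a 2.8-fold lower number from compound 1 to compound 2 (0.45 log units; beyond the scatter). Compound 3 `CCCNC(=O)c1cc(Oc2ccc(NC(=O)c3cc4cccnc4n(-c4ccccc4F)c3=O)cc2)ccn1` differs from compound 1 by ethyl in place of hydrogen on a saturated chain carbon bound to an amide-type nitrogen; in this assay compound 3 gives 390 nM, a step of a 1.5-fold lower number from compound 1 to compound 3 (0.18 log units; within the scatter). Compound 4 `CCCNC(=O)c1cc(Oc2ccc(NC(=O)c3cc4cccnc4n(-c4ccc(F)cc4)c3=O)cc2)ccn1` carries the same change relative to compound 3, namely (4-fluorophenyl in place of 2-fluorophenyl on an aromatic nitrogen), at a place described in identical words, so it is the same change made on the core of compound 3. Because a 2.8-fold lower number from compound 1 to compound 2 (0.45 log units; beyond the scatter) was seen once, a step of similar size is expected, a 2.8-fold lower number from compound 3 to compound 4 (0.44 log units; beyond the scatter). Compound 4 is therefore estimated at 140 nM, most likely between 70 nM and 280 nM.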

Compound 4, half-maximal inhibitory concentration: 120 nM
Compound 4: the middle estimate sits 1.2-fold (0.07 log units) above what was measured; the measured number falls inside the stated range.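

In this assay, 4-fluorophenyl in place of 2-fluorophenyl on the aromatic nitrogen gives a 3.3-fold lower number from compound 3 to compound 4 (0.51 log units; beyond the scatter), and this step agrees with the one seen on the core of compound 1: the same change on two cores in this assay, a 2.8-fold lower number (0.45 log units; beyond the scatter) from compound 1 to compound 2 and a 3.3-fold lower number (0.51 log units; beyond the scatter) from compound 3 to compound 4, 1.2-fold (0.06 log units) apart, within the scatter of two such steps. The ethyl change on the amide chain gives a 1.8-fold lower number from compound 2 to compound 4 (0.24 log units; within the scatter), which stays within the scatter and agrees with its earlier counterpart: the same change on two cores in this assay, a 1.5-fold lower number (0.18 log units; within the scatter) from compound 1 to compound 3 and a 1.8-fold lower number (0.24 log units; within the scatter) from compound 2 to compound 4, 1.2-fold (0.06 log units) apart, within the scatter of two such steps. Each change therefore carried over between these two cores, but four compounds in one cell line show only this single pairing and do not establish that either step would hold on other cores.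

The compounds shown leave open how a plain phenyl or a pyridyl group on the aromatic nitrogen would compare. They also leave open whether a longer chain or a cyclopropyl group on the amide nitrogen would keep these steps the same.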